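Cytotoxicity notes on the biaryl amide series

The source may hold more compounds than are shown below. What is called first, only, known or untested is meant among the compounds shown, and "the series" means these compounds.

Compound 3 `CCOC(=O)CCCCCOc1cccc(CN(C(=O)c2ccc(-c3cc(OC)ccc3F)cc2)C(C)C)c1` carries a 2-fluoro-5-methoxyphenyl group on the shared core. In an ADME assay on BJ cells (Homo sapiens) for cytotoxicity, read by CellTiter-Glo and resazurin assay, with a stated time of 72 h (a lower number here means that less compound is needed, a higher number that more compound is needed for the effect), compound 3 gives > 26000 nM, which is a limit of the assay and not a number. Compound 1 `CCOC(=O)CCCCCOc1cccc(CN(C(=O)c2ccc(-c3ccc(C(C)=O)s3)cc2)C(C)C)c1` gives > 26000 nM in this assay, again a limit. Compound 2 `CCOC(=O)CCCCCOc1cccc(CN(C(=O)c2ccc(-c3cc(OC)cc(OC)c3)cc2)C(C)C)c1` gives > 26000 nM, also a limit. Because (the limit of > 26000 nM in this assay, at which 3 of the 3 values shown sit), the steps a step that the two limits leave unreadable from compound 1 to compound 2, a step that the two limits leave unreadable from compound 1 to compound 3 and a step that the two limits leave unreadable from compound 2 to compound 3 cannot be sized; none of the three aryl groups tried so far has brought the value below the limit.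

Compound 4 `CCOC(=O)CCCCCOc1cccc(CN(C(=O)c2ccc(-c3cccc(Br)c3)cc2)C(C)C)c1` differs from compound 3 by 3-bromophenyl in place of 2-fluoro-5-methoxyphenyl on an aromatic carbon. Among the measured compounds shown here, no measured step bears directly on this change, and the three steps that exist all stay at the limit, so no movement beyond the scatter is expected in this assay. Compound 4 is therefore expected to give about 40000 nM (range 20000 nM to 100000 nM), most likely as another limit. The step that the limit leaves unreadable from compound 3 to compound 4 expected for compound 4 is accordingly small.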

Compound 4, half-maximal effective concentration: > 26000 nM
Compound 4: no number, only a limit (the forecaster's own chance of this, stated with the estimate: 85%); the middle value lies beyond the limit too.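

Compound 4 stays at a limit in this assay, so the steps linking it to compound 1, compound 2 and compound 3 cannot be read: the limit of > 26000 nM in this assay, at which 4 of the 4 values shown sit.

On these data alone, whether these four compounds differ at all in this assay, and whether any aryl group on the shared core would give a readable number, stays open.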